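Swapping Acetyl for Isopropyl: Another Limit Is Expected

The source may report more compounds than this note shows. Statements on the series, on what has been measured and on what is new or still open speak of the compounds shown alone.

Measured in an assay on isolated protein (COS cells) for inhibition of diacylglycerol lipase-alpha (Homo sapiens); a higher number here means a weaker inhibitor, a lower number a stronger inhibitor:
compound 1, `CC(=O)Cn1nnc(Cc2ccc(-c3ccccc3)cc2)n1`, gives > 10000 nM, which is a limit of the assay rather than a number.
compound 2, `CC(C)Cn1nnc(Cc2ccc(-c3ccccc3)cc2)n1`, gives > 10000 nM, again only a limit.
compound 3, `CC(=O)Cn1nnc(CNC(=O)c2ccc(-c3ccccc3)cc2)n1`, gives > 10000 nM, also a limit.

Compound 4, `CC(C)Cn1nnc(CNC(=O)c2ccc(-c3ccccc3)cc2)n1`, is not yet measured. From compound 1 to compound 2 the change is isopropyl in place of acetyl on a saturated chain carbon bound to an aromatic nitrogen, and the resulting step, a step that the two limits leave unreadable from compound 1 to compound 2, cannot be read because both values are limits. The difference between the core of compound 1 and the core of compound 3 is not broken down here. From compound 3 to compound 4 the change is isopropyl in place of acetyl on a saturated chain carbon bound to an aromatic nitrogen, the same change at the same place. Since (the limit of > 10000 nM in this assay, at which 3 of the 3 values shown sit), no listed compound gives a number. Compound 4 is therefore expected to stay at the limit, with an estimated step that the limit leaves unreadable from compound 3 to compound 4. The estimate for compound 4 is 20000 nM, between 8000 nM and 60000 nM.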

Compound 4, half-maximal inhibitory concentration: > 10000 nM
Compound 4 ended at the assay's limit; the forecaster's own chance of this, stated with the estimate: 90%; the middle value lies beyond the limit too.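

Compound 3 and compound 4 both give only a limit of the assay, not a number, and the step between them cannot be read. The compounds shown leave open whether isopropyl in place of acetyl changes inhibition at all.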